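Swapping carbamoyl for carboxy on compound 2

The source may report more compounds than this note shows. Statements on the series, on what has been measured and on what is new or still open speak of the compounds shown alone.

In a functional assay on the whole organism (stomach) with Rattus norvegicus as the target (on this read-out higher numbers stand for an effect only at larger amounts of compound and lower numbers for an effect already at smaller amounts), compound 1 (`O=C(O)c1ccc(C(=O)Nc2cc(C(=O)O)cc(C(=O)O)c2)cc1`) gives 32.2 mg/kg and compound 2 (`N#Cc1ccc(C(=O)Nc2cc(C(N)=O)cc(C(=O)O)c2)cc1`) gives 87.2 mg/kg as the higher of the two numbers, a gap beyond the usual scatter. Compound 3 (`N#Cc1ccc(C(=O)Nc2cc(C(=O)O)cc(C(=O)O)c2)cc1`) differs from compound 2 by one change (hydroxy in place of amino on a carbonyl carbon), hydroxy in place of amino on a carbonyl carbon. Compound 1 also carries carboxy at that place and stands at 32.2 mg/kg on the lower side. The expected 2.2-fold lower number from compound 2 to compound 3 (0.34 log units; beyond the scatter) in this assay is therefore a moderate fall in the number, little beyond the scatter. For compound 3 the estimated value is 40 mg/kg within an expected range of 15 mg/kg to 95 mg/kg in this read-out.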

Compound 3, dose for 50% inhibition: 32.1 mg/kg
Beside the measured number, compound 3's estimate is 1.2-fold (0.10 log units) above it; the range from low to high includes it.
By their numbers in this assay, from the lowest: compounds 3 and 1 (each within the scatter of the next); then compound 2.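

In this assay, hydroxy in place of amino on a carbonyl carbon gives a 2.7-fold lower number from compound 2 to compound 3 (0.43 log units; beyond the scatter), which shows that this single-atom exchange, carbamoyl to carboxy, registers at this place. Cyano in place of carboxy on an aromatic carbon gives a 1.0-fold lower number from compound 1 to compound 3 (0.00 log units; within the scatter), so the read-out does not separate these two groups at that other place. No measurement on hand accounts for either result. As far as these compounds go, whether the cyano and carboxy exchange would read the same with carbamoyl on the carbonyl carbon stays open. From the compounds shown here alone, how a methyl ester or a tetrazole would stand at that place also stays open.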